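Halogen Change on the Hydroxyphenyl Ring

A few compounds are considered here, and "the series" means these few. Any claim that something is new, unique, unknown or untested is made for them only; others in the source may bear on it.

compound 1 `Cc1c(C(=O)N/N=C\c2cc(F)ccc2O)oc2cccc(O)c12` 5230 nM
compound 2 `Cc1ccc(O)c(/C=N\NC(=O)c2oc3cccc(O)c3c2C)c1` 5990 nM
compound 3 `Cc1c(C(=O)N/N=C\c2cc(Cl)ccc2O)oc2cccc(O)c12` 4160 nM

In a functional assay on MGC-803 cells (Homo sapiens) for inhibition, read by MTT assay (a lower number here means a stronger inhibitor, a higher number a weaker inhibitor), compound 3 gives the lowest of the three numbers, yet the steps of a 1.3-fold lower number from compound 1 to compound 3 (0.10 log units; within the scatter) and a 1.4-fold lower number from compound 2 to compound 3 (0.16 log units; within the scatter) both stay within the scatter, so compound 3 cannot be set apart from compound 1 or compound 2. Compound 4 `Cc1c(C(=O)N/N=C\c2cccc(F)c2O)oc2cccc(O)c12` has not been measured. It differs from compound 3 by 3-fluoro-2-hydroxyphenyl in place of 5-chloro-2-hydroxyphenyl on a carbon with a double bond to nitrogen. Within the data shown here, the one measured step that bears on this change, a 1.3-fold lower number from compound 1 to compound 3 (0.10 log units; within the scatter), exchanged one halogen for another and stayed within the scatter; the shift from 5-chloro to 3-fluoro has no measured counterpart. No step beyond the scatter is therefore expected from compound 3 to compound 4, namely a 1.2-fold higher number from compound 3 to compound 4 (0.08 log units; within the scatter). Compound 4 is estimated at 5000 nM, within a range from 2500 nM to 10000 nM.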

Compound 4, half-maximal inhibitory concentration: 8350 nM
For compound 4 the middle estimate is 1.7-fold (0.22 log units) below the measured one, and the stated range covers the measured number.
By their numbers in this assay, from the lowest: compounds 3, 1, 2 and 4 (each within the scatter of the next).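

In this assay, among these compounds, the 3-fluoro-2-hydroxyphenyl group differs from the 5-fluoro-2-hydroxyphenyl group only in where the fluoro stands, and this is the first change of that kind. That change gives a 1.6-fold higher number from compound 1 to compound 4 (0.20 log units; within the scatter) and the other two comparisons give a 1.4-fold higher number from compound 2 to compound 4 (0.14 log units; within the scatter) and a 2.0-fold higher number from compound 3 to compound 4 (0.30 log units; within the scatter), so the new group cannot be set apart from the three before it. Nothing available accounts for these numbers.

Still open, going by these compounds, is whether a 3-chloro-2-hydroxyphenyl group would also stay within the scatter. The same is true of a ring carrying an amine or a carboxylic acid in place of the halogen.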